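Lengthening the Alkyl Chain on a Shared Core

This account rests on a few compounds, and the source may have more. Where it says the series, first, only, none or still open, it means among the compounds named here.

Measured in a functional assay on L1210 cells (Mus musculus) for antiproliferative activity; on this read-out lower numbers stand for an effect already at smaller amounts and higher numbers for an effect only at larger amounts of compound:
Compound 1, `CCCCCO/N=C/c1cc(OC)c2c(c1OC)C(=O)C=CC2=O`: 0.175 ug/mL
Compound 2, `CCCO/N=C/c1cc(OC)c2c(c1OC)C(=O)C=CC2=O`: 0.107 ug/mL

Among the compounds with values here, compound 2 stands at one end of these two numbers, and the only step recorded so far, a 1.6-fold lower number from compound 1 to compound 2 (0.21 log units; within the scatter), connects it to compound 1. Within the data shown here, that step, cut one bond further out, reads as pentyl to propyl, so it is the one piece of evidence on chain length here.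

Compound 3, `CCCCCCCCCO/N=C/c1cc(OC)c2c(c1OC)C(=O)C=CC2=O`, is not yet measured. It differs from compound 2 by hexyl in place of hydrogen on a saturated chain carbon, three bonds along the chain from an oxygen on an unsaturated carbon. Among the measured compounds shown here, the single step that bears on this change lies within the scatter, and its direction was a somewhat higher number for the longer chain. Compound 3 carries a far longer chain than either measured compound, so the expectation rests on thin ground. Compound 3 is therefore expected to show a step of a 2.8-fold higher number from compound 2 to compound 3 (0.45 log units; beyond the scatter) in this assay. The estimated value of compound 3 is 0.3 ug/mL, in a range from 0.1 ug/mL to 1 ug/mL.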

Compound 3, concentration for half-maximal effect: 0.19 ug/mL
Beside the measured number, compound 3's estimate is 1.6-fold (0.20 log units) above it, and the stated range covers the measured number.
By their numbers in this assay, from the lowest: compounds 2, 1 and 3 (each within the scatter of the next).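

In this assay, compound 3 carries the comparison far beyond pentyl: the hexyl change gives a 1.8-fold higher number from compound 2 to compound 3 (0.25 log units; within the scatter), and the butyl change gives a 1.1-fold higher number from compound 1 to compound 3 (0.04 log units; within the scatter). Both steps stay within the scatter, so the propyl, pentyl and nonyl chains on the shared core cannot be told apart on this read-out, even with this much added chain. The earlier single step could not show that the much longer nonyl chain would also leave the number within the scatter, and nothing on hand accounts for this result.

From the compounds shown here alone, it remains open whether a chain ending in an amine or a carboxylic acid, or a phenyl ring in place of the chain, would move the number beyond the scatter. Going by these compounds, whether a methyl or ethyl chain would do so also remains open.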